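The source may hold more compounds than are shown below. What is called first, only, known or untested is meant among the compounds shown, and "the series" means these compounds.

Measured so far:
compound 1, `CC(O)(COc1cc(C(F)(F)F)cc(C(F)(F)F)c1)C(=O)Nc1cccc(S(F)(F)(F)(F)F)c1` – 2800 nM
compound 2, `CC(O)(COc1ccc(S(F)(F)(F)(F)F)cc1)C(=O)Nc1cc(C(F)(F)F)cc(C(F)(F)F)c1` – 2400 nM
compound 3, `CC(O)(COc1ccc(C(F)(F)C(F)(F)F)cc1)C(=O)Nc1cc(C(F)(F)F)cc(C(F)(F)F)c1` – 3000 nM

All three were tested in a functional assay on VCaP cells (Homo sapiens) for antiproliferative activity, read by propidium iodide staining, with a stated time of 96 h; a higher number here means a weaker inhibitor, a lower number a stronger inhibitor. Compound 1 gives 2800 nM, compound 2 gives 2400 nM, and compound 3 gives 3000 nM; each pair of these values lies within the usual scatter of repeated measurements, so no order among them can be read.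

Compound 1 and compound 2 are built from the same atoms joined differently; the difference between the two cores is not broken down here. Compound 2 and compound 3 differ in one place: a group of 7 heavy atoms (2 carbon, 5 fluorine; no ring) in place of a group of 6 heavy atoms (5 fluorine, 1 sulfur; no ring), on an aromatic carbon. That change gave a 1.3-fold higher number from compound 2 to compound 3 (0.10 log units; within the scatter).

Compound 4, `CC(O)(COc1cc(C(F)(F)F)cc(C(F)(F)F)c1)C(=O)Nc1cccc(C(F)(F)C(F)(F)F)c1`, has not yet been measured. It arises from compound 1 by a group of 7 heavy atoms (2 carbon, 5 fluorine; no ring) in place of a group of 6 heavy atoms (5 fluorine, 1 sulfur; no ring), on an aromatic carbon. Among the compounds with values here, this is the same kind of change as the one from compound 2 to compound 3, though the surroundings differ: in compound 2 the group sits para to a large group, whereas in compound 1 it sits meta to a large group.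

Because the earlier change gave a 1.3-fold higher number from compound 2 to compound 3 (0.10 log units; within the scatter), a step of similar size is expected here, a 1.2-fold higher number from compound 1 to compound 4 (0.07 log units; within the scatter). Compound 4 is therefore estimated at 3300 nM, most likely between 1500 nM and 7000 nM.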

Compound 4, half-maximal inhibitory concentration: 8000 nM
Compound 4: middle estimate off by 2.4-fold (0.38 log units), on the low side; the whole stated range lies below it.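

In this assay, putting 1,1,2,2,2-pentafluoroethyl in place of the group of one sulfur and five fluorines gave a 2.9-fold higher number from compound 1 to compound 4 (0.46 log units; beyond the scatter). Set beside the same change made on the other core, the two steps cannot be told apart, even though only the new one lies beyond the scatter on its own: the same change on two cores in this assay, a 1.3-fold higher number (0.10 log units; within the scatter) from compound 2 to compound 3 and a 2.9-fold higher number (0.46 log units; beyond the scatter) from compound 1 to compound 4, 2.3-fold (0.36 log units) apart, within the scatter of two such steps. The two pairs therefore fit a change that carries from one core to the other with a similar effect, but they do not show that the core alters the step, and two pairs are too few to prove that the step is truly the same or that it would hold on any further core.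

The compounds shown leave open how a nitrile, an amine or a longer fluorinated chain would compare at this same place on the ring. They also leave open whether the change would give a similar step on a core carrying a carboxylic acid.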